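From Carboxy to Carbamoyl at the Solubility Limit

The source may hold more compounds than are shown below. What is called first, only, known or untested is meant among the compounds shown, and "the series" means these compounds.

In a physicochemical assay for solubility, read by nephelometry, measured as kinetic solubility, at pH 2 (on this read-out lower numbers stand for lower solubility and higher numbers for higher solubility), compound 1 `O=C(Nc1ccc(C(=O)O)cc1)Nc1ccc(F)c(C(F)(F)F)c1` gives < 1.6 ug/mL, which is a limit of the assay and not a number. Compound 2 `O=C(Nc1ccc(F)c(C(F)(F)F)c1)Nc1ccc(F)c(C(F)(F)F)c1` likewise gives only a limit, < 1.6 ug/mL. Compound 1 therefore stands at the limit of < 1.6 ug/mL in this assay, at which 2 of the 2 values shown sit. Compound 3 `NC(=O)c1ccc(NC(=O)Nc2ccc(F)c(C(F)(F)F)c2)cc1` carries amino in place of hydroxy on a carbonyl carbon, the change from carboxy to carbamoyl: amino in place of hydroxy on a carbonyl carbon. Among the compounds with values here, no measured step yet shows what this change does in this assay. The expected step, an at least 1.2-fold higher number from compound 1 to compound 3 (0.09 log units; that floor lies within the scatter), is none beyond the scatter. For compound 3 the estimate is 2 ug/mL, with an expected range from 1 ug/mL to 6 ug/mL.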

Compound 3, solubility: 6.3 ug/mL
The estimate for compound 3 lay 3.2-fold (0.50 log units) below the measured number; the measured number lies above the stated range.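

In this assay, within the data shown here, the change from carboxy to carbamoyl gives the first readable step at this position, an at least 3.9-fold higher number from compound 1 to compound 3 (0.59 log units; beyond the scatter). Compound 1 gives < 1.6 ug/mL, which is a limit of the assay and not a number. Compound 3 alone among the compounds shown gives a number rather than a limit: the limit of < 1.6 ug/mL in this assay, at which 2 of the 3 values shown sit.

As far as these compounds go, how far compound 1 lies beyond its limit stays open, so the full size of the step cannot be read. Also open, from the compounds shown here alone, is whether a methylamino or a methoxy group on the same carbonyl carbon would give a readable number in this assay.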